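Amide substituent change on the shared core, compound 3 to 4

The source may report more compounds than this note shows. Statements on the series, on what has been measured and on what is new or still open speak of the compounds shown alone.

Measured compounds:
compound 1, `O=C(O)c1ccc2noc(-c3ccc(-c4ccncc4)cc3)c2c1`, 150 nM
compound 2, `O=C(O)c1ccc2noc(-c3ccc(Oc4ccccc4)cc3)c2c1`, 280 nM
compound 3, `CC(C)C(=O)Nc1ccc(-c2onc3ccc(C(=O)O)cc23)cc1`, 820 nM

All three share one core and differ only in the group on the distal aromatic carbon. In an assay for inhibition of inositol hexakisphosphate kinase 2 (Homo sapiens), read by colorimetric assay, coupled enzyme assay and malachite green, with a stated time of 120 min, in the presence of a further agent that is not named here (a higher number here means a weaker inhibitor, a lower number a stronger inhibitor), compound 3 gives 820 nM, the highest number of the three. One gap is a 5.5-fold higher number from compound 1 to compound 3 (0.74 log units; beyond the scatter); the other gap is a 2.9-fold higher number from compound 2 to compound 3 (0.47 log units; beyond the scatter). Compound 1 and compound 2 sit close together, a 1.9-fold higher number from compound 1 to compound 2 (0.27 log units; within the scatter).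

Compound 4, `O=C(O)c1ccc2noc(-c3ccc(NC(=O)C4CCCC4)cc3)c2c1`, keeps the amide of compound 3 and changes only the group on its carbonyl carbon: cyclopentyl in place of isopropyl on a carbonyl carbon.

Among the compounds with values here, no measured step varies this position. The steps that exist all exchange the whole substituent on the aromatic carbon, and the two that involve compound 3 are modest in size. The change to compound 4 is smaller in kind than any of them, so no step beyond the scatter is expected in this assay, in either direction.

Compound 4 is therefore estimated at 650 nM, with a range of 250 nM to 1700 nM, meaning an expected step of a 1.3-fold lower number from compound 3 to compound 4 (0.10 log units; within the scatter).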

Compound 4, half-maximal inhibitory concentration: 190 nM
Compound 4: the middle estimate sits 3.4-fold (0.53 log units) above what was measured, and the stated range ends above it.
By their numbers in this assay, from the lowest: compounds 1, 4 and 2 (each within the scatter of the next); then compound 3.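

In this assay, within the data shown here, the group on the carbonyl carbon proves to be a position that moves the number: cyclopentyl in place of isopropyl gives a 4.3-fold lower number from compound 3 to compound 4 (0.64 log units; beyond the scatter), a step the earlier compounds could not show, as each of their steps exchanged the whole substituent on the aromatic carbon. The high number of compound 3 therefore does not belong to the amide as such, since the (cyclopentylcarbonyl)amino group stands level with the two groups that carry no amide, with a 1.5-fold lower number from compound 2 to compound 4 (0.17 log units; within the scatter) and a 1.3-fold higher number from compound 1 to compound 4 (0.10 log units; within the scatter). Nothing available bears on the reason for this step.

This single pair changes the ring and the carbon count together, so it cannot separate the two, and an open pentyl chain, cyclobutyl or cyclohexyl on the same carbonyl carbon would be needed to tell them apart. From the compounds shown here alone, it also remains open whether the step holds for a carbonyl substituent carrying an amine or a carboxylic acid, or for phenyl in place of cyclopentyl.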